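From phenyl to pyridin-4-yl on compound 3

The source may report more compounds than this note shows. Statements on the series, on what has been measured and on what is new or still open speak of the compounds shown alone.

In a functional assay on A549 cells (Homo sapiens) for cytotoxicity, read by MTT assay, with a stated time of 72 h (a higher number here means a weaker inhibitor, a lower number a stronger inhibitor), compound 1 `O=C(CN1CCN(c2nnc(Cc3ccncc3)c3ccccc23)CC1)Nc1cccc(F)c1` gives 4600 nM and compound 2 `Cc1ccc(F)cc1NC(=O)CN1CCN(c2nnc(Cc3ccncc3)c3ccccc23)CC1` gives 38900 nM. Compound 3 `O=C(CN1CCN(c2nnc(Cc3ccccc3)c3ccccc23)CC1)Nc1cc(C(F)(F)F)ccc1Cl` gives 89000 nM, the highest number of the three and so the weakest inhibitor among them. Compound 4 `O=C(CN1CCN(c2nnc(Cc3ccncc3)c3ccccc23)CC1)Nc1cc(C(F)(F)F)ccc1Cl` has not yet been measured. It differs from compound 3 in one place: pyridin-4-yl in place of phenyl on a saturated chain carbon bound to an aromatic carbon. In words, benzyl becomes (pyridin-4-yl)methyl.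

For the measured compounds named here, no measured pair isolates this swap. Going by the values given here, the only measured step, an 8.5-fold higher number from compound 1 to compound 2 (0.93 log units; beyond the scatter), is a methyl in place of hydrogen on an aromatic carbon, so it shows only that one small change in these compounds can move the number beyond the scatter. Compound 1 at 4600 nM and compound 2 at 38900 nM both carry pyridin-4-yl and both sit lower than compound 3, but each also differs from it elsewhere. A modest fall is therefore expected, an estimated 3.0-fold lower number from compound 3 to compound 4 (0.47 log units; beyond the scatter). Compound 4 is estimated at 30000 nM, with an expected range from 7000 nM to 120000 nM.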

Compound 4, half-maximal inhibitory concentration: 1850 nM
Beside the measured number, compound 4's estimate is 16-fold (1.21 log units) above it; the whole stated range lies above it.
By their numbers in this assay, from the lowest: compound 4; then compound 1; then compound 2; then compound 3.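

Swapping phenyl for pyridin-4-yl on this saturated chain carbon gives a 48-fold lower number from compound 3 to compound 4 (1.68 log units; beyond the scatter) in this assay, so this one change of a ring carbon to a ring nitrogen can turn the weakest of these compounds into the strongest. The group on the amide-type nitrogen also matters when pyridin-4-yl is present: 2-chloro-5-(trifluoromethyl)phenyl gives a 21-fold lower number from compound 2 to compound 4 (1.32 log units; beyond the scatter) when it replaces 5-fluoro-2-methylphenyl, and a 2.5-fold lower number from compound 1 to compound 4 (0.40 log units; beyond the scatter) when it replaces 3-fluorophenyl. Nothing available here explains the size of these steps.

From the compounds shown here alone, whether pyridin-3-yl or pyridin-2-yl would give a similar step remains open. So does whether the phenyl to pyridin-4-yl swap would have a similar effect with 3-fluorophenyl or 5-fluoro-2-methylphenyl on the amide-type nitrogen.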